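Fluorobenzyl Amide Analog of Three Inactive Nitro Sulfones

This account rests on a few compounds, and the source may have more. Where it says the series, first, only, none or still open, it means among the compounds named here.

Measured in an assay on isolated protein for inhibition of thyroid hormone receptor alpha (Homo sapiens), read by fluorescence polarization; a lower number here means a stronger inhibitor, a higher number a weaker inhibitor:
Compound 1, `CS(=O)(=O)c1ccc(C(=O)NCCCC(=O)N2Cc3ccccc3C2)cc1[N+](=O)[O-]`, gives a limit of > 60000 nM.
Compound 2, `CCCN(C(=O)CN(C)C(=O)c1ccc(S(C)(=O)=O)c([N+](=O)[O-])c1)c1ccccc1`, gives a limit of > 60000 nM.
Compound 3, `CS(=O)(=O)c1ccc(C(=O)NCCC(=O)N2CCCc3ccccc32)cc1[N+](=O)[O-]`, gives a limit of > 60000 nM.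

Compound 1 stands at the limit of this assay, with no number obtained, and the other two compounds sit at the same limit (the limit of > 60000 nM in this assay, at which 3 of the 3 values shown sit). Compound 4, `CN(Cc1ccccc1F)C(=O)CCCNC(=O)c1ccc(S(C)(=O)=O)c([N+](=O)[O-])c1`, differs from compound 1 on a carbonyl carbon: a group of 10 heavy atoms (8 carbon, 1 nitrogen, 1 fluorine; one six-membered aromatic ring of carbon only) in place of a group of 9 heavy atoms (8 carbon, 1 nitrogen; one five-membered non-aromatic ring with 1 hetero atom, one six-membered aromatic ring of carbon only), on a carbonyl carbon. Going by the values given here, no step between measured compounds exists to set a scale for this change, and the three measured compounds offer only limits. A shift beyond the scatter in either direction is therefore not expected. The expected step that the limit leaves unreadable from compound 1 to compound 4 is about nothing. Compound 4 is estimated at 80000 nM, in a range from 30000 nM to 300000 nM, most likely again reported only as a limit.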

Compound 4, half-maximal inhibitory concentration: > 60000 nM
Compound 4: only a limit was reported; the forecaster's own chance of this, stated with the estimate: 85%; the middle value lies beyond the limit too.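

No step can be read from compound 1 to compound 4, since both values are limits: the limit of > 60000 nM in this assay, at which 4 of the 4 values shown sit.

The compounds shown leave open whether any change to this shared core gives a measurable value in this assay.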